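The compounds below may be only part of what the source reports. "The series", "measured", "known", "first", "only" and "open" are said of these compounds alone.

Measured compounds in a functional assay on ECa-109 cells for inhibition, with ECa-109 cell line (Homo sapiens) as the target, read by sulforhodamine B assay; on this read-out lower numbers stand for stronger inhibition and higher numbers for weaker inhibition:
- compound 1 `Cc1ccc(NC2=CC(=O)c3c(nc4n3[C@H]3OC[C@@H](O)[C@H]3OC4)C2=O)cc1C`: 4090 nM
- compound 2 `O=C1C=C(Nc2ccc(C(F)(F)F)cc2)C(=O)c2c1nc1n2[C@H]2OC[C@@H](O)[C@H]2OC1`: 5500 nM
- compound 3 `CCCN(CCC)C1=CC(=O)c2nc3n(c2C1=O)[C@H]1OC[C@@H](O)[C@H]1OC3`: > 16000 nM

Of the compounds shown here, three sharing one core have been measured in this assay. Compound 1 gives the lower of the two numbers, yet compound 2 stands close to it and the gap between them lies within the usual scatter, so no order can be drawn between these two. The value of compound 3, which carries a dipropylamino group on the core, is a limit of the assay rather than a number.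

Compound 4 `O=C1C(NC2CCCCC2)=CC(=O)c2c1nc1n2[C@H]2OC[C@@H](O)[C@H]2OC1` has not been measured yet. It differs from compound 1 in one place: cyclohexyl in place of 3,4-dimethylphenyl on an amine nitrogen. A six-membered aromatic ring of carbon only leaves and a six-membered non-aromatic ring of carbon only enters, on the amine nitrogen whose other neighbour is a double-bonded ring carbon.

Among the measured compounds shown here, no step between measured compounds is known here, so the expectation for compound 4 rests on the values shown. The step from compound 1 to compound 4 is expected to be a 2.2-fold higher number from compound 1 to compound 4 (0.34 log units; beyond the scatter), towards weaker inhibition, a lean that draws on (the limit of > 16000 nM in this assay, at which 1 of the 3 values shown sits). Compound 4 is therefore estimated at 9000 nM, with a range from 3500 nM to 20000 nM.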

Compound 4, half-maximal inhibitory concentration: > 16000 nM
Compound 4: a limit, no number; the forecaster's own chance of this, stated with the estimate: 35%; at least 1.7-fold (0.24 log units) between middle value and limit.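

In this assay, among the compounds shown here, the change from 3,4-dimethylphenyl to cyclohexylamino-bearing compound 4 gives the first step that can be read at this position: an at least 3.9-fold higher number from compound 1 to compound 4 (0.59 log units; beyond the scatter), towards weaker inhibition. The earlier compounds shown here offered no such single-place comparison, so only now can it be said that the group on this amine nitrogen matters, and that a six-membered non-aromatic ring of carbon only does not stand in for the six-membered aromatic ring of compound 1. The value of compound 4, > 16000 nM, is a limit of the assay and not a number, so the step gives only the least size of the loss, and the limit now recurs among the compounds shown: the limit of > 16000 nM in this assay, at which 2 of the 4 values shown sit.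

The step also leaves unresolved whether the loss follows the aromatic ring itself or the methyl groups on it, a question that an unsubstituted phenyl group on the same amine nitrogen would address. From the compounds shown here alone, whether a benzyl group, which sets an aromatic ring one carbon further out, or a pyridyl ring would hold a measurable number at this position also stays open.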